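The source may hold more compounds than are shown below. What is called first, only, known or untested is meant among the compounds shown, and "the series" means these compounds.

Measured compounds:
compound 1, `CCCC[S+]([O-])c1sc2nc(-c3nccs3)cc(-c3ccc(C(C)(C)O)cc3)c2c1N`, 3.6 nM
compound 2, `COCCC[S+]([O-])c1sc2nc(-c3nccs3)cc(-c3cnc(C)n3C)c2c1N`, 3.3 nM
compound 3, `CCCC[S+]([O-])c1sc2nc(-c3nccs3)cc(-c3nccs3)c2c1N`, 1.8 nM

In an assay for inhibition of 15-hydroxyprostaglandin dehydrogenase [NAD(+)] (Homo sapiens), read by fluorescence, with a stated time of 15 min, in the presence of a further agent that is not named here (a lower number here means a stronger inhibitor, a higher number a weaker inhibitor), compound 3 gives the lowest of the three numbers, but its separation from the others is small: compound 2 gives 3.3 nM and compound 1 gives 3.6 nM, and both gaps lie within the scatter of this assay, so no order among the three can be claimed.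

Compound 4, `CCCC[S+]([O-])c1sc2nc(-c3nccs3)cc(-c3cnc(C)[nH]3)c2c1N`, has not yet been measured. It differs from compound 3 in one place: 2-methyl-1H-imidazol-5-yl in place of 1,3-thiazol-2-yl on an aromatic carbon. Among the measured compounds shown here, only one measured step touches the same position: a 2.0-fold lower number from compound 1 to compound 3 (0.30 log units; within the scatter), a change within the scatter. Compound 2, which carries a methyl-bearing imidazole ring of its own at that position together with a different chain on the sulfoxide, also sits within the scatter of compound 3. For the measured compounds named here, no measured pair isolates the change from compound 3 to compound 4 itself.

On this basis the step from compound 3 to compound 4 is expected to stay within the scatter, a 1.7-fold higher number from compound 3 to compound 4 (0.22 log units; within the scatter). Compound 4 is therefore estimated at 3 nM in this assay, with a range from 1.2 nM to 8 nM.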

Compound 4, half-maximal inhibitory concentration: 2.3 nM
The estimate for compound 4 lay 1.3-fold (0.12 log units) above the measured number; measured number inside the range.
By their numbers in this assay, from the lowest: compounds 3, 4, 2 and 1 (each within the scatter of the next).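

In this assay, the aromatic carbon opposite the ring nitrogen accepts 2-methyl-1H-imidazol-5-yl, which carries 1 hydrogen-bond donor, in place of 1,3-thiazol-2-yl, which carries 0, and the swap gives a 1.3-fold higher number from compound 3 to compound 4 (0.11 log units; within the scatter). Set against the larger 4-(1-hydroxy-1-methylethyl)phenyl group, the same imidazole gives a 1.6-fold lower number from compound 1 to compound 4 (0.19 log units; within the scatter), so all three groups, on an otherwise unchanged molecule, now stand within the scatter of one another at this position, and the new donor-bearing ring adds a third kind of group without any step beyond it. Nothing shown offers an explanation for these results.

The compounds shown do not reveal whether any group at this position would move the number beyond the scatter, for instance a carboxylic acid, an amine or a saturated ring such as morpholine. Compound 2 differs from compound 4 in two places, both the methyl on the imidazole ring nitrogen and the chain on the sulfoxide, so the contribution of each change cannot be read separately.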